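Alkylthio uridine monophosphates: methyl to propyl

The compounds below may be only part of what the source reports. "The series", "measured", "known", "first", "only" and "open" are said of these compounds alone.

Compound 1 `CSc1nc(=O)ccn1[C@@H]1O[C@H](COP(=O)(O)O)[C@@H](O)[C@H]1O`: in an in vitro functional assay on 1321-N1 cells for agonist activity at P2Y purinoceptor 6 (Homo sapiens), read by scintillation proximity assay and inositol phosphate accumulation (on this read-out higher numbers stand for an effect only at larger amounts of compound and lower numbers for an effect already at smaller amounts), compound 1 gives > 100000 nM, a limit of the assay.
Compound 2 `CSc1nc(=O)ccn1[C@@H]1O[C@H](COP(=O)(O)OP(=O)(O)O)[C@@H](O)[C@H]1O`: in this assay compound 2 gives 4700 nM.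
Compound 3 `O=c1[nH]c(=S)ccn1[C@@H]1O[C@H](COP(=O)(O)O)[C@@H](O)[C@H]1O`: in this assay compound 3 gives > 100000 nM, also a limit of the assay.

Compound 1 thus stands at the limit (the limit of > 100000 nM in this assay, at which 2 of the 3 values shown sit), where compound 3 sits too. For the measured compounds named here, the only measured step, an at least 21-fold lower number from compound 1 to compound 2 (1.32 log units; beyond the scatter), concerns the phosphate chain and not the group on the sulfur. Compound 4 `CCCSc1nc(=O)ccn1[C@@H]1O[C@H](COP(=O)(O)O)[C@@H](O)[C@H]1O` carries ethyl in place of hydrogen on a saturated chain carbon bound to a sulfur. No measured step alters the substituent on the sulfur, so nothing bears on this change directly; both monophosphates shown rest at the limit. Compound 4 is therefore expected to remain at or near that limit, with the step that the limit leaves unreadable from compound 1 to compound 4 expected to stay within the scatter. The estimate for compound 4 is 150000 nM, ranging from 30000 nM to 600000 nM.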

Compound 4, half-maximal effective concentration: 6200 nM
Compound 4: the middle estimate sits 24-fold (1.38 log units) above what was measured; measured number outside the range, below it.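

In this assay, for the compounds shown here, methyl to propyl on the sulfur gives an at least 16-fold lower number from compound 1 to compound 4 (1.20 log units; beyond the scatter) and is the first measured step at this position, showing that a monophosphate can leave the limit through the chain on the sulfur alone. The phosphate chain stays unchanged in this step. Its true size remains unreadable, as compound 1 gives only a limit of the assay: the limit of > 100000 nM in this assay, at which 2 of the 4 values shown sit.

From the compounds shown here alone, whether ethyl, butyl or a longer chain on the sulfur would give lower numbers remains open, as does the effect of an amine at the chain end. Also open, going by these compounds, is how propyl would act with the longer phosphate chain of compound 2.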